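Swapping a Cyclohexene for a Bicyclic Amide Substituent

A few compounds are considered here, and "the series" means these few. Any claim that something is new, unique, unknown or untested is made for them only; others in the source may bear on it.

Measured compounds:
compound 1, `CC1CC=C(C(=O)N(c2cc(C#CC(C)(C)C)sc2C(=O)O)C(C)C)CC1`, free fraction 0.08
compound 2, `CC(C)(C)C#Cc1cc(N(C(=O)[C@H]2CC[C@H](C)CC2)[C@H]2CC[C@H](O)CC2)c(C(=O)O)s1`, free fraction 0.19

Two compounds sharing the same acid-bearing core have been examined in an ADME assay for protein binding, using equilibrium dialysis, at pH 7.4, tested at 2 uM; on this read-out lower numbers stand for a smaller free fraction and higher numbers for a larger free fraction. Compound 1 shows the lower of the two numbers, and compound 2 sits a gap above it that is larger than the usual scatter of this assay.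

Compound 3, `CC(C)N(C(=O)[C@@H]1CC[C@@H]2C[C@@H]2CC1)c1cc(C#CC(C)(C)C)sc1C(=O)O`, has not yet been measured. It differs from compound 1 at one place: a group of 8 heavy atoms (8 carbon; one three-membered non-aromatic ring of carbon only, one seven-membered non-aromatic ring of carbon only) in place of a group of 7 heavy atoms (7 carbon; one six-membered non-aromatic ring of carbon only), on a carbonyl carbon. The group that enters carries one more heavy atom than the one that leaves, and neither group brings any hydrogen-bond donor or acceptor, so the change is a modest one.

Because compound 1 gives 0.08 in this assay, compound 3 is expected to land close by, with any step a 1.3-fold lower number from compound 1 to compound 3 (0.12 log units; within the scatter) small and likely not beyond the scatter, pointing slightly downward if anywhere. The estimate for compound 3 is 0.06, within a range from 0.03 to 0.12.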

Compound 3, unbound fraction: 0.05
For compound 3 the middle estimate is 1.2-fold (0.08 log units) above the measured one; the measured number falls inside the stated range.
By their numbers in this assay, from the lowest: compounds 3 and 1 (each within the scatter of the next); then compound 2.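

At the carbonyl carbon bonded to the amide-type nitrogen, replacing 4-methylcyclohex-1-en-1-yl with a group of one three-membered and one seven-membered carbon ring gives a 1.6-fold lower number from compound 1 to compound 3 (0.20 log units; within the scatter) in this assay. This read-out therefore does not separate these two all-carbon groups, even though the entering group has a different ring pattern, carries three defined stereocentres and lacks the double bond of the group that leaves. Nothing measured here offers a reason for this result.

On these data alone, whether a ring carrying an amine at this carbonyl carbon would shift the free fraction beyond the scatter remains open. Also open, as far as these compounds go, is whether the mirror-image form of the entering group would give a similar number.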